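The source may hold more compounds than are shown below. What is called first, only, known or untested is meant among the compounds shown, and "the series" means these compounds.

Measured compounds:
compound 1, `C=CCNC(=S)NCCCCn1nc(-c2ccccc2)ccc1=O`, giving 27.1% in a functional assay on the whole organism with Rattus norvegicus as the target, at a dose of 100 mg/kg; a higher number here means more inhibition at the dose given (going by the name of the read-out), a lower number less inhibition
compound 2, `C/N=C(\S)NCCCCn1nc(-c2ccccc2)ccc1=O`, giving 87.1% in this assay
compound 3, `C/N=C(\S)NCCCCCCn1nc(-c2ccccc2)ccc1=O`, giving 22.2% in this assay

Compound 3 stands lowest of the three numbers in this assay, with compound 1 nearest at a difference within the scatter and compound 2 furthest, the gap a number 64.9 percentage points lower from compound 2 to compound 3 (beyond the scatter) lying beyond the scatter. Among the measured steps, a number 60 percentage points higher from compound 1 to compound 2 (beyond the scatter) and a number 4.9 percentage points lower from compound 1 to compound 3 (within the scatter) both change the chain or the group on the amine nitrogen; none of them touches the ring.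

Compound 4, `C/N=C(\S)NCCCCCCn1nc(C)ccc1=O`, differs from compound 3 by methyl in place of phenyl on an aromatic carbon. For the measured compounds named here, no measured step bears on this change, so the measured data give no direction for it. Lacking any comparison on the ring, the step of a number 0.2 percentage points lower from compound 3 to compound 4 (within the scatter) is expected to stay within the scatter, though with wide uncertainty. Compound 4 is therefore estimated at 22% in this assay, within a range from 5% to 45%.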

Compound 4, a percentage reported as inhibition, in the whole organism at one dose (the size of the read-out at that dose, not a potency): -12.5%
Compound 4: middle estimate off by 34.5 percentage points, on the high side, and the stated range ends above it.
By their numbers in this assay, from the lowest: compound 4; then compounds 3 and 1 (each within the scatter of the next); then compound 2.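

This is the first step among the compounds shown that touches the ring rather than the chain or the group on the amine nitrogen. In this assay, methyl in place of phenyl on this aromatic carbon gives a number 34.7 percentage points lower from compound 3 to compound 4 (beyond the scatter), so the group at this position matters for the read-out, at least on the chain of compound 3. For the compounds shown here, compound 4 gives -12.5%, the only number below zero among the four, and nothing measured here accounts for the drop.

From the compounds shown here alone, it remains open whether the same change would have a similar effect on the chain of compound 2, which has the highest number. The results also leave open how an ethyl, a benzyl or an amine at this aromatic carbon would compare with phenyl and methyl.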